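A New Aryl Group on the Aromatic Nitrogen

The source may hold more compounds than are shown below. What is called first, only, known or untested is meant among the compounds shown, and "the series" means these compounds.

Of the compounds shown here, three built on one shared core have been measured in a functional assay on A549 cells (Homo sapiens) for inhibition, read by MTT assay, with a stated time of 72 h; a higher number here means a weaker inhibitor, a lower number a stronger inhibitor. Compound 1 `Cn1ccc2c(Oc3ccc(NC(=O)c4cn(-c5ccccc5)c5ccccc5c4=O)cc3F)ccnc21` carries an unsubstituted phenyl on the aromatic nitrogen of the core and gives 1720 nM. Compound 2 `Cn1ccc2c(Oc3ccc(NC(=O)c4cn(-c5ccc(F)cc5)c5ccccc5c4=O)cc3F)ccnc21` gives 1460 nM, and compound 3 `Cn1ccc2c(Oc3ccc(NC(=O)c4cn(-c5ccc(Br)cc5)c5ccccc5c4=O)cc3F)ccnc21` gives 1390 nM. The steps between them are small: a 1.2-fold lower number from compound 1 to compound 2 (0.07 log units; within the scatter), a 1.2-fold lower number from compound 1 to compound 3 (0.09 log units; within the scatter) and a 1.1-fold lower number from compound 2 to compound 3 (0.02 log units; within the scatter). Compound 3 shows the lowest number of the three, but its steps to compound 1 and compound 2 lie within the scatter, so the three cannot be ranked against one another.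

Compound 4 `Cn1ccc2c(Oc3ccc(NC(=O)c4cn(-c5ccc(C(F)(F)F)cc5Cl)c5ccccc5c4=O)cc3F)ccnc21` differs from compound 3 in one place: 2-chloro-4-(trifluoromethyl)phenyl in place of 4-bromophenyl on an aromatic nitrogen. The new ring carries both a trifluoromethyl and a chlorine in place of the single bromine. All three measured steps concern a single substituent on this ring, and each was within the scatter; none covers a trifluoromethyl or a ring with two substituents, so they bear on the change only loosely. Because a 1.2-fold lower number from compound 1 to compound 3 (0.09 log units; within the scatter) and a 1.1-fold lower number from compound 2 to compound 3 (0.02 log units; within the scatter) were flat, no step beyond the scatter is expected here either. Compound 4 is expected to give 1200 nM, between 400 nM and 3500 nM. That corresponds to an estimated 1.2-fold lower number from compound 3 to compound 4 (0.06 log units; within the scatter).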

Compound 4, half-maximal inhibitory concentration: 2050 nM
For compound 4 the middle estimate is 1.7-fold (0.23 log units) below the measured one; the range from low to high includes it.
By their numbers in this assay, from the lowest: compounds 3, 2, 1 and 4 (each within the scatter of the next).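

In this assay the change to a ring with two substituents, a chlorine and a trifluoromethyl, gives no step beyond the scatter against any earlier ring: not against 4-bromophenyl (a 1.5-fold higher number from compound 3 to compound 4 (0.17 log units; within the scatter)), not against 4-fluorophenyl (a 1.4-fold higher number from compound 2 to compound 4 (0.15 log units; within the scatter)) and not against phenyl (a 1.2-fold higher number from compound 1 to compound 4 (0.08 log units; within the scatter)). The position on the aromatic nitrogen, flat across the three single changes measured before, therefore stays flat when 2-chloro-4-(trifluoromethyl)phenyl enters, and the four compounds cannot be ranked against one another. Nothing available here explains this flatness.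

As far as these compounds go, all four groups at this position are carbon-only aromatic rings bearing hydrogen, halogen or trifluoromethyl, so it remains open whether an amine, a carboxylic acid or a methoxy on the ring would give a step beyond the scatter. Also open, from the compounds shown here alone, is what happens with no aromatic ring on this nitrogen at all, for example with an ethyl or a longer alkyl chain in its place, and whether the same flat picture holds when other parts of the shared core carry different groups.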